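Chain extension in the isothiocyanate series: compound 3 to compound 4

The source may hold more compounds than are shown below. What is called first, only, known or untested is meant among the compounds shown, and "the series" means these compounds.

Compound 1 `CN(C)C(=O)c1cc2cnc(Nc3ccc(C(=O)NCCCCCCCN=C=S)cc3)nc2n1C1CCCC1`, compound 2 `CN(C)C(=O)c1cc2cnc(Nc3ccc(C(=O)NCCCCCN=C=S)cc3F)nc2n1C1CCCC1` and compound 3 `CN(C)C(=O)c1cc2cnc(Nc3ccc(C(=O)NCCCCCCN=C=S)cc3F)nc2n1C1CCCC1` share one core and differ in the amide-linked chain and the fluorine on the aromatic ring. In a functional assay on NCI-H1299 cells (Homo sapiens) for inhibition, read by CCK-8 assay, with a stated time of 72 h, tested at 10 uM (on this read-out higher numbers stand for a stronger effect at the one concentration tested and lower numbers for a weaker effect), compound 1 gives 107%, compound 2 gives 86.7% and compound 3 gives 77.6%. Compound 3 therefore stands lowest of the three numbers, with compound 2 nearest within the scatter and compound 1 furthest, beyond the scatter.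

Compound 4 `CN(C)C(=O)c1cc2cnc(Nc3ccc(C(=O)NCCCCCCCN=C=S)cc3F)nc2n1C1CCCC1` is not yet measured. It differs from compound 3 by a group of 4 heavy atoms (2 carbon, 1 nitrogen, 1 sulfur; no ring) in place of a group of 3 heavy atoms (1 carbon, 1 nitrogen, 1 sulfur; no ring), on a saturated chain carbon, six bonds along the chain from an amide-type nitrogen. Going by the values given here, the one measured step of the same kind, one chain carbon added, is a number 9.1 percentage points lower from compound 2 to compound 3 (within the scatter), within the scatter. Among the compounds with values here, no step to compound 1 is available for this pair, so only its value above is noted. On that basis the step from compound 3 to compound 4 in this assay is expected to be a number 3.6 percentage points lower from compound 3 to compound 4 (within the scatter), that is, no change beyond the scatter, with a slight lean lower in line with the measured step.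

Compound 4 is estimated to give 74% in this assay, within a range from 55% to 93%.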

Compound 4, a percentage reported as inhibition, at one concentration (the size of the read-out at that concentration, not a potency): 35.8%
Beside the measured number, compound 4's estimate is 38.2 percentage points above it; measured number outside the range, below it.
By their numbers in this assay, from the lowest: compound 4; then compounds 3 and 2 (each within the scatter of the next); then compound 1.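

In this assay, chain length at this place no longer reads as flat: extending the chain gives a number 41.8 percentage points lower from compound 3 to compound 4 (beyond the scatter), whereas the earlier extension gave a number 9.1 percentage points lower from compound 2 to compound 3 (within the scatter), and the two extensions together give a number 50.9 percentage points lower from compound 2 to compound 4 (beyond the scatter). Going by these compounds alone, at the chain length of compound 4, fluoro in place of hydrogen on an aromatic carbon goes with a number 71.2 percentage points lower from compound 1 to compound 4 (beyond the scatter), the first reading of that change alone. Nothing measured here bears on what lies behind these drops.

Going by these compounds, it remains open whether a longer chain ending in the isothiocyanate would stay as low as compound 4 or recover, and whether the same chain lengths without the fluoro would follow the same course. On these data alone, it is also open whether an amine in place of the isothiocyanate on the same chain would keep the read-out of compound 3 or compound 4, and, with only one concentration to go on, how these compounds would compare at other concentrations.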